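This account rests on a few compounds, and the source may have more. Where it says the series, first, only, none or still open, it means among the compounds named here.

Measured so far in an assay on HEK293 cells for displacement of a labelled ligand from NPC1-like intracellular cholesterol transporter 1 (Homo sapiens); on this read-out lower numbers stand for stronger inhibition and higher numbers for weaker inhibition: compound 1 `CC(C)(C)c1ccc(C(=O)N2CCC3(CC2)C(=O)N(CC(=O)NCCC(=O)O)CN3c2ccccc2)cc1`, 11400 nM; compound 2 `O=C(CN1CN(c2ccccc2)C2(CCN(C(=O)c3ccc(C4CCCCC4)cc3)CC2)C1=O)N1CCC(CO)CC1`, 1100 nM; compound 3 `CC(C)(C)OC(=O)NCCNC(=O)CN1CN(c2ccccc2)C2(CCN(C(=O)c3ccc(C4CCCCC4)cc3)CC2)C1=O`, 5500 nM.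

Compound 1 gives the highest number of the three; compound 3 stands nearest to it and compound 2 furthest. Compound 4 `CC(C)(C)c1ccc(C(=O)N2CCC3(CC2)C(=O)N(CC(=O)N2CCCCC2CCO)CN3c2ccccc2)cc1` keeps the core of compound 1 and differs from it only in the change (2-(2-hydroxyethyl)piperidin-1-yl in place of (2-carboxyethyl)amino on a carbonyl carbon). Among the measured compounds shown here, the one measured step that bears on this is a 5.0-fold higher number from compound 2 to compound 3 (0.70 log units; beyond the scatter), where (2-((tert-butoxycarbonyl)amino)ethyl)amino replaced 4-(hydroxymethyl)piperidin-1-yl on a carbonyl carbon; the step from compound 1 to compound 4 runs the other way, from an open chain to a piperidinyl ring. Compounds 1 and 4 share one core, compounds 2 and 3 another, so the parallel is loose. A step toward lower numbers of about that size is expected, a 3.8-fold lower number from compound 1 to compound 4 (0.58 log units; beyond the scatter). Compound 4 is estimated at 3000 nM, with a range of 1000 nM to 9000 nM.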

Compound 4, half-maximal inhibitory concentration: 6100 nM
Compound 4: middle estimate off by 2.0-fold (0.31 log units), on the low side, within the range that was stated.
By their numbers in this assay, from the lowest: compound 2; then compounds 3, 4 and 1 (each within the scatter of the next, the first and the last beyond it).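

On the core of compound 1, 2-(2-hydroxyethyl)piperidin-1-yl in place of (2-carboxyethyl)amino on a carbonyl carbon gives a 1.9-fold lower number from compound 1 to compound 4 (0.27 log units; within the scatter) and so does not separate the two groups at this position. Among the compounds shown here, this is the first single-place step read on this core, and here replacing the open chain bearing a carboxylic acid with a hydroxyl-bearing ring yields no step beyond the scatter. Nothing available explains this result.

Still open, as far as these compounds go, is how an unsubstituted piperidin-1-yl would read on this core. The same applies to an open chain ending in an amine rather than a carboxylic acid.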